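The source may report more compounds than this note shows. Statements on the series, on what has been measured and on what is new or still open speak of the compounds shown alone.

Among the compounds with values here, in an in vitro ADME assay on microsomes from liver (Homo sapiens) for metabolic stability (on this read-out lower numbers stand for a shorter-lived compound and higher numbers for a longer-lived compound), compound 2 `CS(=O)(=O)Nc1ccc2c(c1)S(=O)(=O)C=C(c1c(O)c(-c3cccs3)nn(CC3CCCC3)c1=O)N2` gives 0.717 h, the only actual number so far. Compound 1 `CC(C)CCn1nc(-c2cccs2)c(O)c(C2=CS(=O)(=O)c3cc(NS(C)(=O)=O)ccc3N2)c1=O` is reported only as a limit, > 1 h. Compound 3 `CS(=O)(=O)Nc1ccc2c(c1)S(=O)(=O)C=C(c1c(O)c(-c3cccs3)nn(Cc3ccccc3)c1=O)N2` differs from compound 2 by phenyl in place of cyclopentyl on a saturated chain carbon bound to an aromatic nitrogen, with phenyl in place of cyclopentyl on a saturated chain carbon bound to an aromatic nitrogen. Within the data shown here, the single measured step at that place, an at least 1.3-fold lower number from compound 1 to compound 2 (0.14 log units; that floor lies within the scatter), rests on a limit and stays within the scatter, so no change beyond the scatter is expected. The estimated step is a 1.1-fold lower number from compound 2 to compound 3 (0.04 log units; within the scatter). For compound 3 the expected half-life is 0.65 h, with an estimated range of 0.35 h to 1 h.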

Compound 3, half-life: > 1 h
Compound 3: a limit, no number (the forecaster's own chance of this, stated with the estimate: 20%); middle value at least 1.5-fold (0.18 log units) away from the limit.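

In this assay, compound 3 gives a limit and not a number, so an aromatic phenyl at this place reads no shorter-lived than the saturated cyclopentyl. The change shows an at least 1.3-fold higher number from compound 2 to compound 3 (0.14 log units; that floor lies within the scatter), which means that the measured floor alone does not separate the two groups. The step from compound 1 to compound 3 cannot be read, and the values stop at one shared ceiling: the limit of > 1 h in this assay, at which 2 of the 3 values shown sit. From the compounds shown here alone, how far compound 1 and compound 3 lie past that limit stays open. So does how an amine or a carboxylic acid would read on a saturated chain carbon bound to an aromatic nitrogen.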